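Urea series: trifluoromethyl in place of methoxy

This account rests on a few compounds, and the source may have more. Where it says the series, first, only, none or still open, it means among the compounds named here.

Measured compounds:
compound 1 `Cc1ccc(Nc2cc(NC(=O)Nc3c(Cl)cccc3Cl)ncn2)cc1F` — 40.7%
compound 2 `COc1cc(Nc2cc(NC(=O)Nc3c(Cl)cccc3Cl)ncn2)cc(OC)c1` — 60%
compound 3 `COc1cc(NC(=O)Nc2cc(Nc3cc(C)cc(F)c3)ncn2)cc(OC)c1` — 35.3%

In a functional assay on NCI-H226 cells (Homo sapiens) for inhibition, read by MTT assay, with a stated time of 48 h, tested at 10 uM (a higher number here means more inhibition at the concentration tested (going by the name of the read-out), a lower number less inhibition), compound 2 gives 60%, the highest of the three numbers. Compound 1 gives 40.7% in this assay, a difference from compound 2 that lies beyond the usual scatter. Compound 3 gives 35.3% in this assay, which is the furthest of the three from compound 2 and also beyond the scatter. No pair among these three differs in one place only, so no single step can be traced.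

Compound 4 `COc1cc(Nc2cc(NC(=O)Nc3c(Cl)cccc3Cl)ncn2)cc(C(F)(F)F)c1` has not yet been measured. It differs from compound 2 in one place: trifluoromethyl in place of methoxy on an aromatic carbon. Among the measured compounds shown here, no measured pair shows this change, so its effect can only be guessed. The expectation is a small downward step from compound 2 in this assay, a number 8 percentage points lower from compound 2 to compound 4 (within the scatter), a size that would not clearly exceed the scatter. On that basis compound 4 is estimated at 52%, with a range from 30% to 74%.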

Compound 4, a percentage reported as inhibition, at one concentration (the size of the read-out at that concentration, not a potency): 33.1%
Compound 4: middle estimate off by 18.9 percentage points, on the high side, within the range that was stated.
By their numbers in this assay, from the lowest: compounds 4, 3 and 1 (each within the scatter of the next); then compound 2.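

In this assay, among the compounds shown here, trifluoromethyl in place of methoxy on an aromatic carbon gives a number 26.9 percentage points lower from compound 2 to compound 4 (beyond the scatter), the first change that can be read at a single place. The inhibition at the concentration tested therefore depends on the group at this position, meta to a methoxy group, and methoxy and trifluoromethyl are not interchangeable here on the core of compound 2. Nothing measured here bears on the reason for this step.

With a single replacement shown at this position, it remains open whether the step reflects the loss of methoxy or the arrival of trifluoromethyl; a hydrogen, a chlorine, an ethoxy or an amine there would help separate the two. Equally open, as far as these compounds go, is whether the same replacement on the methoxy-bearing ring of compound 3 would give a step of similar size.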